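A few compounds are considered here, and "the series" means these few. Any claim that something is new, unique, unknown or untested is made for them only; others in the source may bear on it.

For the measured compounds named here, only two compounds in this small series have been measured so far. In a functional assay on UO-31 cells (Homo sapiens) for inhibition (a lower number here means a stronger inhibitor of growth, a higher number a weaker inhibitor of growth), compound 1 `COc1cc(-c2nncn2-c2ccc(N(C)C)cc2)cc(OC)c1OC` gives 955 nM and compound 2 `COc1ccc(-n2cnnc2-c2cc(OC)c(OC)c(OC)c2)cc1O` gives 501 nM. These two values lie within the usual scatter of repeated measurements, so compound 2 stands level with compound 1 and neither can be called the better inhibitor.

The next compound, compound 3 `COc1ccc(-n2cnnc2-c2cc(OC)c(OC)c(OC)c2)cc1F`, keeps the whole of compound 2 except for one group: fluoro in place of hydroxy on an aromatic carbon, ortho to a methoxy group and meta to a large group (fluoro in place of hydroxy on an aromatic carbon). Going by the values given here, the two measured compounds differ in more than one place, and no measured step shows what this swap does. Any expectation here is therefore a cautious one, and it leaves room for no real change at all.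

In this assay, a modest move toward a higher number, meaning a somewhat weaker inhibitor, is expected, and the estimated step is a 1.6-fold higher number from compound 2 to compound 3 (0.20 log units; within the scatter). For compound 3 the estimated value is 800 nM, with an expected range from 250 nM to 2800 nM.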

Compound 3, concentration for 50% growth inhibition: 17800 nM
Compound 3: the middle estimate sits 22-fold (1.35 log units) below what was measured, outside the stated range (above it).
By their numbers in this assay, from the lowest: compounds 2 and 1 (each within the scatter of the next); then compound 3.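

In this assay, the swap of fluoro for hydroxy gives a 36-fold higher number from compound 2 to compound 3 (1.55 log units; beyond the scatter), so this position, ortho to a methoxy group, is far from indifferent to what sits on it, and a change of a single heavy atom is enough to lose much of the growth inhibition. On paper, hydroxy counts one hydrogen-bond donor and one hydrogen-bond acceptor and fluoro counts neither, but one step cannot show whether that difference is what matters. Nothing measured here bears on why the number rises so far.

An amino group or a plain hydrogen at this same position would help show whether hydroxy itself holds the lower number, or whether fluoro is what drives it up. For the compounds shown here, also open is whether the same swap would have a step of this size in a compound with other groups elsewhere, as this single pair is the only reading of the change so far.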